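Notes on ring-for-chain exchange at the core nitrogen

The compounds below may be only part of what the source reports. "The series", "measured", "known", "first", "only" and "open" are said of these compounds alone.

Measured so far:
- compound 1, `COc1ccc(-c2c(-c3ccc(OC)cc3)n(Cc3ccccc3)c3ncn(CCCO)c(=N)c23)cc1`: 0.36 h
- compound 2, `COc1ccc(Cn2c(-c3ccccc3)c(-c3ccccc3)c3c(=N)n([C@H]4CC[C@H](O)CC4)cnc32)cc1`: 2 h

Within the data shown here, in an ADME assay on microsomes from liver (Mus musculus, strain CD1) for metabolic stability, read by LC-MS, using NADPH, with a stated time of 60 min (on this read-out lower numbers stand for a shorter-lived compound and higher numbers for a longer-lived compound), compound 1 gives 0.36 h and stands lowest of the two numbers; its only neighbour is compound 2, which in this assay gives 2 h, a gap beyond the scatter. Compound 2 differs from compound 1 in several places at once, so its value cannot be tied to any single change.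

Compound 3, `COc1ccc(-c2c(-c3ccc(OC)cc3)n(Cc3ccccc3)c3ncn(C4CCOCC4)c(=N)c23)cc1`, has not yet been measured. It differs from compound 1 in one place: oxan-4-yl in place of 3-hydroxypropyl on an aromatic nitrogen. Among the measured compounds shown here, no step between measured compounds carries this exchange, so the expectation rests only on the two values shown. For the measured compounds named here, compound 2, the one measured compound that bears a ring rather than a chain on the corresponding nitrogen, gives 2 h; on that slender basis a step from compound 1 to compound 3 of a 1.9-fold higher number from compound 1 to compound 3 (0.29 log units; within the scatter) in this assay is expected, upward, of modest size and possibly within the scatter. For compound 3 in this assay the estimate is 0.7 h, with a range of 0.3 h to 1.6 h.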

Compound 3, half-life: 0.978 h
Compound 3: middle estimate off by 1.4-fold (0.15 log units), on the low side, within the range that was stated.
By their numbers in this assay, from the lowest: compound 1; then compound 3; then compound 2.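

In this assay, oxan-4-yl in place of 3-hydroxypropyl on the aromatic nitrogen gives a 2.7-fold higher number from compound 1 to compound 3 (0.43 log units; beyond the scatter), with nothing else in the structure changed. Among these compounds, this is the first step that can be tied to a single place, and it shows that the group on this nitrogen can move the half-life beyond the usual scatter, although only modestly. The exchange brings several differences at once, a six-membered non-aromatic ring in place of an open chain and 0 hydrogen-bond donors in place of 1, and no measurement bears on which of them matters.

Ring closure and loss of the hydroxyl remain tied together in this single step, so a 3-methoxypropyl chain, which keeps the open chain without the hydroxyl, or a cyclohexyl ring, which has no ring oxygen, would be needed on the same nitrogen to pull them apart. Also open is how a basic amine such as piperidin-4-yl, or a carboxylic acid on a longer chain, would behave at this position, since the groups shown here are all neutral.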